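Solubility notes: sulfonamide series, compound 1 to compound 4

This account rests on a few compounds, and the source may have more. Where it says the series, first, only, none or still open, it means among the compounds named here.

Measured so far:
compound 1 `COc1ccc(S(=O)(=O)Nc2ccc(CN3CCN(C(=O)C4CN(C(C)=O)C4)CC3)cc2)cc1` — >= 511000 nM
compound 2 `Cc1ccc(S(=O)(=O)Nc2ccc(CN(C)[C@@H]3CCN(C(=O)c4cccc(Cl)c4)C3)cc2)cc1` — 28000 nM
compound 3 `Cc1ccc(S(=O)(=O)Nc2ccc(CN3C[C@@H]4CN(C(=O)c5cccc(Cl)c5)C[C@@H]4C3)cc2)cc1` — 25000 nM

In a physicochemical assay for solubility, measured as kinetic solubility (a lower number here means a less soluble compound, a higher number a more soluble compound), compound 1 returns only a limit of the assay, >= 511000 nM, not a number. That reading sits at the top end of what this assay reports: the limit of >= 511000 nM in this assay, at which 1 of the 3 values shown sits. Compound 2 gives 28000 nM in this assay, and compound 3 gives 25000 nM. These two lie within the usual scatter of each other; no ordering between them is claimed. Among the measured compounds shown here, no pair of the measured compounds differs in one place only, so no single measured step is available to calibrate the change studied here.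

Compound 4 `COc1ccc(S(=O)(=O)Nc2ccc(CN3CCN(C(=O)Cn4cccnc4=O)CC3)cc2)cc1` is not yet measured in this assay. It differs from compound 1 as follows:
a group of 8 heavy atoms (5 carbon, 2 nitrogen, 1 oxygen; one six-membered aromatic ring with 2 hetero atoms) in place of a group of 7 heavy atoms (5 carbon, 1 nitrogen, 1 oxygen; one four-membered non-aromatic ring with 1 hetero atom), on a carbonyl carbon

With compound 1 already at a limit in this assay, the step from compound 1 to compound 4 cannot be read as a rise; the expectation is that compound 4 stays at or near that same limit, so an at least 1.4-fold lower number from compound 1 to compound 4 (0.16 log units; that floor lies within the scatter) is estimated as no change beyond the scatter, or a modest fall if a number is returned. Compound 4 is therefore estimated at 350000 nM in this assay, within 80000 nM to 600000 nM.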

Compound 4, solubility: >= 336000 nM
Compound 4 gave a limit, no number; the forecaster's own chance of this, stated with the estimate: 55%; the middle value is on the limit's open side.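

Compound 1 and compound 4 both return only limits of the assay in this assay, so the step between them cannot be read. The compounds shown leave open whether replacing the 1-acetylazetidin-3-yl group on the carbonyl carbon changes the read-out in this assay at all, and in which direction.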